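The compounds below may be only part of what the source reports. "The series", "measured", "known", "first", "only" and "open" are said of these compounds alone.

Measured so far in an assay on blood for inhibition of C-X-C chemokine receptor type 3 (Homo sapiens), with a stated time of 30 min; on this read-out higher numbers stand for weaker inhibition and lower numbers for stronger inhibition: compound 1 `CCOc1ncc(-c2nc(C(F)(F)F)sc2N2CCN(C(=O)Cn3nc(C)nc3C)[C@H](C)C2)cn1` gives 364 nM; compound 2 `COc1ncc(-c2nc(C(F)(F)F)sc2N2CCN(C(=O)Cn3nc(C)nc3C)[C@H](C)C2)cn1` gives 1040 nM; compound 3 `CCc1ncc(-c2nc(C(F)(F)F)sc2N2CCN(C(=O)Cn3nc(C)nc3C)[C@H](C)C2)cn1` gives 567 nM.

On these numbers compound 3 stands second highest of the three, with compound 1 its nearest neighbour and compound 2 its furthest, both within the scatter, so no ranking among them is secure. Compound 4 `CCCc1ncc(-c2nc(C(F)(F)F)sc2N2CCN(C(=O)Cn3nc(C)nc3C)[C@H](C)C2)cn1` differs from compound 3 by methyl in place of hydrogen on a saturated chain carbon, two bonds along the chain from an aromatic carbon. For the measured compounds named here, the only step that speaks to chain length at that spot is a 2.9-fold higher number from compound 1 to compound 2 (0.46 log units; beyond the scatter), the reverse of adding one carbon; the steps of a 1.6-fold higher number from compound 1 to compound 3 (0.19 log units; within the scatter) and a 1.8-fold lower number from compound 2 to compound 3 (0.26 log units; within the scatter) swap the group on the ring instead and stay within the scatter. Growing ethyl to propyl is therefore expected to lower the number only slightly, probably within the scatter, as a 1.4-fold lower number from compound 3 to compound 4 (0.13 log units; within the scatter). Compound 4 is expected to give about 420 nM, between 200 nM and 900 nM.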

Compound 4, half-maximal inhibitory concentration: 367 nM
Beside the measured number, compound 4's estimate is 1.1-fold (0.06 log units) above it, within the range that was stated.
By their numbers in this assay, from the lowest: compounds 1, 4, 3 and 2 (each within the scatter of the next, the first and the last beyond it).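

In this assay ethyl and propyl cannot be told apart, a 1.5-fold lower number from compound 3 to compound 4 (0.19 log units; within the scatter), and propyl on the aromatic carbon reads the same as ethoxy, a 1.0-fold higher number from compound 1 to compound 4 (0.00 log units; within the scatter), whereas the step from methoxy to propyl lies beyond the scatter, a 2.8-fold lower number from compound 2 to compound 4 (0.45 log units; beyond the scatter). Taking one methyl off the chain reads alike in the oxygen-linked pair and in the all-carbon pair, the first step beyond the scatter and the second within it, yet the two agree: the same change on two cores in this assay, a 2.9-fold higher number (0.46 log units; beyond the scatter) from compound 1 to compound 2 and a 1.5-fold higher number (0.19 log units; within the scatter) from compound 4 to compound 3, 1.8-fold (0.27 log units) apart, within the scatter of two such steps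

The compounds shown leave open whether a butyl chain keeps the number near these values or moves it. An amine or a carboxylic acid on this aromatic carbon is likewise untested in these data.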